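Swapping the aryl group on the shared core

A few compounds are considered here, and "the series" means these few. Any claim that something is new, unique, unknown or untested is made for them only; others in the source may bear on it.

Three compounds have values so far in a functional assay on trachea (Cavia porcellus) for inhibition (a higher number here means a weaker inhibitor, a lower number a stronger inhibitor), as follows
- compound 1 `COC(=O)C1=C(C)NC(C)=C(C(=O)OC)C1c1c(-c2ccc(C(F)(F)F)cc2)nc2sccn12` (measured at 61 nM)
- compound 2 `CCOC(=O)C1=C(C)NC(C)=C(C(=O)OCC)C1c1c(-c2ccc(C(F)(F)F)cc2)nc2sccn12` (measured at 130 nM)
- compound 3 `COC(=O)C1=C(C)NC(C)=C(C(=O)OC)C1c1c(C(F)(F)F)nc2sc(C)cn12` (measured at 31 nM)

Compound 1 stands in the middle of the three numbers at 61 nM in this assay with compound 3 within the scatter of it and compound 2 beyond the scatter on the higher side.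

Compound 4 `COC(=O)C1=C(C)NC(C)=C(C(=O)OC)C1c1c(-c2cccc(OC(F)(F)F)c2)nc2sccn12` has not yet been measured. It keeps the core of compound 1 and carries 3-(trifluoromethoxy)phenyl in place of 4-(trifluoromethyl)phenyl on an aromatic carbon at the same place. Both groups hold one six-membered aromatic ring of carbon only. Among the compounds with values here, no measured pair isolates a change at this place, so the expectation rests on the structural change alone. No step beyond the scatter is expected in this assay here, only a slight lean toward a higher number. The expected move is a 1.3-fold higher number from compound 1 to compound 4 (0.12 log units; within the scatter) by this estimate. For compound 4 the estimate is 80 nM with an expected range from 25 nM to 250 nM in all.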

Compound 4, half-maximal inhibitory concentration: 58 nM
For compound 4 the middle estimate is 1.4-fold (0.14 log units) above the measured one, and the stated range covers the measured number.
By their numbers in this assay, from the lowest: compounds 3, 4 and 1 (each within the scatter of the next); then compound 2.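

In this assay, within the data shown here, this place on the shared core now has its first readable step: 3-(trifluoromethoxy)phenyl in place of 4-(trifluoromethyl)phenyl gives a 1.1-fold lower number from compound 1 to compound 4 (0.02 log units; within the scatter), the only step so far between compounds that differ in one place. On this aromatic carbon, next to the ring nitrogen, the two groups cannot be told apart in this read-out, although the entering group adds an oxygen and a hydrogen-bond acceptor. Nothing available explains why the two groups read alike.

The compounds shown leave open how an amine or a carboxylic acid would read at this place, and whether an unsubstituted phenyl would match these two groups. They also leave open whether this swap would read the same with the ethyl esters of compound 2.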